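The source may hold more compounds than are shown below. What is called first, only, known or untested is meant among the compounds shown, and "the series" means these compounds.

Measured so far in a functional assay on SW1573 cells (Homo sapiens) for antiproliferative activity, read by sulforhodamine B assay, with a stated time of 48 h; on this read-out lower numbers stand for stronger inhibition of growth and higher numbers for weaker inhibition of growth:
compound 1 `COC(=O)C#CC(O/C=C/C(=O)OC)C1CC1` gives 1800 nM;
compound 2 `COC(=O)C#CC(CC(C)C)O/C=C/C(=O)OC` gives 380 nM;
compound 3 `COC(=O)C#CC(O/C=C/C(=O)OC)C(C)C` gives 750 nM.

Compound 3 stands second highest of the three numbers: compound 2 lies within the scatter of it (a 2.0-fold higher number from compound 2 to compound 3 (0.30 log units; within the scatter)), compound 1 beyond it (a 2.4-fold lower number from compound 1 to compound 3 (0.38 log units; beyond the scatter)). All three measured steps, including a 4.7-fold lower number from compound 1 to compound 2 (0.68 log units; beyond the scatter), vary the group on the saturated chain carbon bound to an oxygen on an unsaturated carbon and a triple-bonded carbon; none touches the methoxycarbonyl. Compound 4 `CCOC(=O)C#CC(O/C=C/C(=O)OC)C(C)C` differs from compound 3 by methyl in place of hydrogen on a saturated chain carbon bound to an oxygen next to a carbonyl group. Within the data shown here, no measured step bears on this change, so no step beyond the scatter is expected in this assay; the estimated step is no change at the digits printed from compound 3 to compound 4 (within the scatter). Compound 4 is therefore expected near 750 nM, with a range from 350 nM to 1600 nM.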

Compound 4, concentration for 50% growth inhibition: 960 nM
For compound 4 the middle estimate is 1.3-fold (0.11 log units) below the measured one; low and high end bracket the measured number.
By their numbers in this assay, from the lowest: compounds 2, 3, 4 and 1 (each within the scatter of the next, the first and the last beyond it).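

In this assay, among these compounds, the change from methoxycarbonyl to ethoxycarbonyl gives a 1.3-fold higher number from compound 3 to compound 4 (0.11 log units; within the scatter) and is the first step away from the group varied earlier. One added methyl at this place thus leaves the number within the scatter, at least with isopropyl on the chain carbon.

Open, on these data alone, is whether a longer chain or a carboxylic acid here would stay within the scatter, and whether the same change holds with isobutyl or cyclopropyl in place of isopropyl. No evidence at hand bears on this result.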